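This account rests on a few compounds, and the source may have more. Where it says the series, first, only, none or still open, it means among the compounds named here.

Compound 1 `Cn1cc(C2=C(c3nn(CCCn4cccc4)c4ncccc34)C(=O)N(c3ccccc3)C2=O)c2ccccc21` gives > 100000 nM in a functional assay on A549 cells (Homo sapiens) for antiproliferative activity, read by MTT assay, with a stated time of 48 h (a higher number here means a weaker inhibitor, a lower number a stronger inhibitor), a limit of the assay rather than a number. Compound 2 `Cn1cc(C2=C(c3nn(CCCCn4ccnc4)c4ncccc34)C(=O)NC2=O)c2ccccc21` gives 2380 nM in this assay. Compound 3 `CN1CCN(CCCn2nc(C3=C(c4cn(C)c5ccccc45)C(=O)NC3=O)c3cccnc32)CC1` gives > 100000 nM in this assay, again a limit.

Compound 1 thus sits at the limit of > 100000 nM in this assay, at which 2 of the 3 values shown sit, the weakest end of what this assay reports. The unmeasured compound 4 `CN(C)CCCn1nc(C2=C(c3cn(C)c4ccccc34)C(=O)N(c3ccccc3)C2=O)c2cccnc21` differs from it by dimethylamino in place of 1H-pyrrol-1-yl on a saturated chain carbon, three bonds along the chain from an aromatic nitrogen. Among the compounds with values here, no measured step matches that change; the only step among the measured compounds, an at least 42-fold higher number from compound 2 to compound 3 (1.62 log units; beyond the scatter), swaps a chain-end group as well but on a core lacking the phenyl on the imide nitrogen. It offers no evidence that an amine at the chain end restores activity. Compound 4 is therefore expected to remain at the limit, an estimated 100000 nM (20000 nM to 300000 nM), a step of a number no higher from compound 1 to compound 4 (the limit leaves the size open).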

Compound 4, half-maximal inhibitory concentration: 13000 nM
Beside the measured number, compound 4's estimate is 7.7-fold (0.89 log units) above it; measured number below the stated range.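

On the core of compound 1, the chain end can carry activity: dimethylamino in place of 1H-pyrrol-1-yl gives an at least 7.6-fold lower number from compound 1 to compound 4 (0.88 log units; beyond the scatter) in this assay. The earlier step at this place, an at least 42-fold higher number from compound 2 to compound 3 (1.62 log units; beyond the scatter), had shown only a loss, and on a core without the phenyl. Compound 1 stands at a limit of the assay, so the new step gives only a minimum size: the limit of > 100000 nM in this assay, at which 2 of the 4 values shown sit.

The compounds shown leave open whether morpholine or pyrrolidine at the chain end, or a longer chain bearing dimethylamino, would change the number further. They also leave open how dimethylamino behaves on the core of compound 2.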